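The source may report more compounds than this note shows. Statements on the series, on what has been measured and on what is new or still open speak of the compounds shown alone.

Two compounds of a shared core carry an ester on the side-chain methylene. Compound 1 `COc1cc(C(=O)N2CCN(C(=O)c3cc(OC)c(OC)c(OC)c3)C(COC(=O)C(C)(C)C)C2)cc(OC)c1OC` bears a pivalate there; in a functional assay (Oryctolagus cuniculus) for inhibition of platelet-activating factor receptor (Cavia porcellus) (a higher number here means a weaker inhibitor, a lower number a stronger inhibitor), compound 1 gives 100 nM; 100 nM; 120 nM (3 entries). Within the data shown here, compound 2 `COc1cc(C(=O)N2CCN(C(=O)c3cc(OC)c(OC)c(OC)c3)C(COC(=O)CC(C)(C)C)C2)cc(OC)c1OC` carries the ester of a neopentyl-bearing acid instead, and in this assay compound 2 gives 120 nM, the single number it has there, with one further entry that reports no number. The values of compound 1 and compound 2 lie within the usual scatter of each other, as the several entries of compound 1 in this assay, 100 nM; 100 nM; 120 nM (3 entries) shows for compound 1 alone.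

Compound 3 `CCCCNC(=O)OCC1CN(C(=O)c2cc(OC)c(OC)c(OC)c2)CCN1C(=O)c1cc(OC)c(OC)c(OC)c1` has not yet been measured. It differs from compound 2 in one place: butylamino in place of neopentyl on a carbonyl carbon, so the ester becomes a butylcarbamate. Among the measured compounds shown here, no measured pair here follows such a change, and the two esters give no hint of a sensitivity to this end of the molecule. The step from compound 2 to compound 3 is therefore expected to be small, a 1.3-fold higher number from compound 2 to compound 3 (0.10 log units; within the scatter), with no clear direction. Compound 3 is estimated at 150 nM, between 60 nM and 400 nM.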

Compound 3, half-maximal inhibitory concentration: 240 nM
The estimate for compound 3 lay 1.6-fold (0.20 log units) below the measured number; the measured number falls inside the stated range.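

In this assay, butylamino in place of neopentyl on a carbonyl carbon, which turns the ester into a butylcarbamate, gives a 2.0-fold higher number from compound 2 to compound 3 (0.30 log units; within the scatter). This is the first step shown at this position, and it shows that the linkage itself can be exchanged and a hydrogen-bond donor brought in while the two numbers stay within the usual scatter of each other. A single step of this size cannot be read as a real loss, since repeated entries of one compound also spread: the several entries of compound 1 in this assay, 100 nM; 100 nM; 120 nM (3 entries)

The compounds shown leave open whether the hydrogen on the carbamate nitrogen matters, which a dimethylamino group in place of butylamino would address. They also say nothing about how a longer chain such as octylamino, or a phenylamino group, would read in this assay.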